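Benzyl to 3-phenylpropyl: notes on compound 3

A few compounds are considered here, and "the series" means these few. Any claim that something is new, unique, unknown or untested is made for them only; others in the source may bear on it.

Compound 1 `O=C(NO)c1cccc(-c2cn([C@@H]3C[C@@H](CO)N(Cc4ccccc4)C3)nn2)c1` in an assay on Sf9 cells for inhibition of histone deacetylase 11 (Homo sapiens), read by fluorescence, tested at 0.5 uM; on this read-out higher numbers stand for more inhibition at the one concentration tested (going by the name of the read-out) and lower numbers for less inhibition: < 10%, a limit of the assay.
Compound 2 `O=C(NO)c1cccc(-c2cn([C@H]3C[C@@H](CO)N(Cc4ccccc4)C3)nn2)c1` in this assay: < 10%, likewise a limit.

Both measured values sit at the limit (the limit of < 10% in this assay, at which 2 of the 2 values shown sit), so compound 1 stands only at a limit, with no number of its own. Within the data shown here, the single measured step, a step that the two limits leave unreadable from compound 1 to compound 2, rests on a change of configuration alone the fact that compounds 1 and 2 differ only in the configuration as drawn and leaves no readable size. Compound 3 `O=C(NO)c1cccc(-c2cn([C@@H]3C[C@@H](CO)N(CCCc4ccccc4)C3)nn2)c1` differs from compound 1 by phenethyl in place of phenyl on a saturated chain carbon bound to an amine nitrogen in a ring. No measured step bears on this change: the one step shown concerns configuration, not the group on that carbon, and its size cannot be read. Nothing therefore points to a rise beyond the scatter, and the two limits give no floor from which a fall could be read. Compound 3 is expected to remain near the limit, the estimated step being a step that the limit leaves unreadable from compound 1 to compound 3. The estimate for compound 3 is 8%, between 0% and 25%.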

Compound 3, a percentage reported as inhibition, at one concentration (the size of the read-out at that concentration, not a potency): < 10%
Compound 3: no number, only a limit (the forecaster's own chance of this, stated with the estimate: 70%); the middle value lies beyond the limit too.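

In this assay, among these compounds, compound 3 gives < 10%, a limit of the assay, so no step from compound 1 to compound 3 can be read. The compounds shown leave open whether benzyl, 3-phenylpropyl or the configuration as drawn makes any difference to the read-out in this assay.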